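Benzyl for methoxyethoxymethyl on a cytotoxic pyrrolopyrimidine core

This account rests on a few compounds, and the source may have more. Where it says the series, first, only, none or still open, it means among the compounds named here.

Three compounds have been measured in a functional assay on KB cells (Homo sapiens) for cytotoxicity; on this read-out lower numbers stand for stronger inhibition and higher numbers for weaker inhibition:
Compound 1, `NC(=O)c1cn(Cc2ccccc2)c2ncnc(N)c12`, gives 75000 nM.
Compound 2, `COCCOCn1cc(C(N)=O)c2c(N)ncnc21`, gives only a limit of the assay, > 100000 nM.
Compound 3, `COCCOCn1cc(C#N)c2c(N)ncnc21`, likewise gives only a limit of the assay, > 100000 nM.

Compound 4, `N#Cc1cn(Cc2ccccc2)c2ncnc(N)c12`, has not been measured yet.

Compound 2 and compound 1 differ in one place: phenyl in place of 2-methoxyethoxy on a saturated chain carbon bound to an aromatic nitrogen. This change gave an at least 1.3-fold lower number from compound 2 to compound 1 (0.12 log units; that floor lies within the scatter). Its size is blurred because of the limit of > 100000 nM in this assay, at which 2 of the 3 values shown sit.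

Compound 2 and compound 3 differ elsewhere: cyano in place of carbamoyl on an aromatic carbon. Here the step was a step that the two limits leave unreadable from compound 2 to compound 3.

The change from compound 3 to compound 4 is the same one seen from compound 2 to compound 1: phenyl in place of 2-methoxyethoxy on a saturated chain carbon bound to an aromatic nitrogen, at the very same place. The two starting cores differ by the carbamoyl-to-cyano exchange just described. Since compound 3 sits at a limit of the assay, only the lower end of its true value is known, and any step from it can only be read loosely.

The expectation for compound 4 therefore rests on the step of an at least 1.3-fold lower number from compound 2 to compound 1 (0.12 log units; that floor lies within the scatter) applied to a starting point known only as a limit. On that basis compound 4 is expected to show a step of about an at least 1.1-fold lower number from compound 3 to compound 4 (0.04 log units; that floor lies within the scatter), with a fair chance that it too comes back as a limit. The estimate for compound 4 is 90000 nM, within a range from 40000 nM to 200000 nM.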

Compound 4, half-maximal inhibitory concentration: > 100000 nM
Compound 4: only a limit was reported; the forecaster's own chance of this, stated with the estimate: 55%; at least 1.1-fold (0.04 log units) between middle value and limit.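

In this assay compound 4 gives > 100000 nM, which is a limit of the assay and not a number. So the swap of 2-methoxyethoxy for phenyl on a saturated chain carbon bound to an aromatic nitrogen cannot be followed from the carbamoyl core to the cyano core: the steps with a limit at both ends cannot be read, and the result neither confirms nor refutes that the change carries over, for this reason: the limit of > 100000 nM in this assay, at which 3 of the 4 values shown sit.

For the compounds shown here, the one new step that can be read, cyano in place of carbamoyl on an aromatic carbon, is an at least 1.3-fold higher number from compound 1 to compound 4 (0.12 log units; that floor lies within the scatter), so it sets only a floor and gives no firm evidence that the two groups differ in this assay.

Among the compounds shown, only compound 1 has a true number, 75000 nM, so there is no second measured value against which to test the phenyl change. On these data alone, how a carboxylic acid in place of carbamoyl on the aromatic carbon, or a longer chain in place of phenyl on the saturated chain carbon, would read in this assay remains open.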